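A few compounds are considered here, and "the series" means these few. Any claim that something is new, unique, unknown or untested is made for them only; others in the source may bear on it.

Compound 1 `FC(F)(F)c1ccc(-c2nn(-c3ccccc3)cc2CNc2ccc(Cl)cc2)cc1` gives 44000 nM
Compound 2 `FC(F)(F)c1ccc(NCc2cn(-c3ccccc3)nc2-c2ccc(Cl)cc2)cc1` gives 31000 nM

In an ADME assay on MDBK cells (Bos taurus) for cytotoxicity, read by MTT assay, with a stated time of 72 h (a lower number here means that less compound is tolerated, a higher number that more compound is tolerated), compound 1 at 44000 nM and compound 2 at 31000 nM lie within the scatter of each other, so compound 1 has no measured neighbour clearly apart from it. Compound 3 `FC(F)(F)c1ccc(-c2nn(-c3ccccc3)cc2CNc2ccc(Br)cc2)cc1` keeps the core of compound 1 and carries bromo in place of chloro on an aromatic carbon. Among the measured compounds shown here, no measured step shows what this change does. The expected step is none beyond the scatter, in no clear direction (a 1.2-fold lower number from compound 1 to compound 3 (0.06 log units; within the scatter)). For compound 3 the estimated value is 38000 nM with 17000 nM to 75000 nM as the expected range.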

Compound 3, half-maximal cytotoxic concentration: 64000 nM
Beside the measured number, compound 3's estimate is 1.7-fold (0.23 log units) below it, within the range that was stated.
By their numbers in this assay, from the lowest: compounds 2, 1 and 3 (each within the scatter of the next, the first and the last beyond it).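

In this assay, bromo in place of chloro on an aromatic carbon, para to a large group, gives a 1.5-fold higher number from compound 1 to compound 3 (0.16 log units; within the scatter), the first step measured at this position. The step lies within the scatter, so this exchange of one halogen for the other shows no clear effect on the number here. No evidence is available to explain the reading. At this position the compounds shown carry only chloro and bromo, so whether a methoxy group, a nitrile or an amine would move the number beyond the scatter stays open.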